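This account rests on a few compounds, and the source may have more. Where it says the series, first, only, none or still open, it means among the compounds named here.

Measured compounds and their minimum effective doses:
compound 1 `CC(=O)N1CCCN(S(=O)(=O)c2ccc(F)cc2)CC1`: 1 mg/kg
compound 2 `CCC(=O)N1CCCN(S(=O)(=O)c2ccc(F)cc2)CC1`: 1 mg/kg
compound 3 `CCC(=O)N1CCN(C(C)=O)CC1`: 10 mg/kg

In a functional assay on the whole organism with Mus musculus as the target (on this read-out higher numbers stand for an effect only at larger amounts of compound and lower numbers for an effect already at smaller amounts), compound 1 gives 1 mg/kg. Compound 2 carries the change methyl in place of hydrogen on a saturated chain carbon bound to a carbonyl carbon on the core of compound 1, and in this assay compound 2 gives 1 mg/kg; the step of no change at the digits printed from compound 1 to compound 2 (within the scatter) lies within the scatter. Compound 3 stands on a different core; the difference between the two cores is not broken down here. In this assay compound 3 gives 10 mg/kg, the highest number of the three and beyond the scatter from both compound 1 and compound 2.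

Compound 4 `CCC(=O)N1CCN(C(=O)CC)CC1` is not yet measured. It differs from compound 3 by methyl in place of hydrogen on a saturated chain carbon bound to a carbonyl carbon, the same change as from compound 1 to compound 2, at a place described in the same words. Because no change at the digits printed from compound 1 to compound 2 (within the scatter) showed no movement on the first core, the step from compound 3 to compound 4 is expected to be about no change at the digits printed from compound 3 to compound 4 (within the scatter). On that basis compound 4 is estimated at 10 mg/kg, between 5 mg/kg and 20 mg/kg, with the caveat that the transfer rests on a single pair and the cores differ.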

Compound 4, minimum effective dose: > 10 mg/kg
Compound 4: only a limit was reported; the forecaster's own chance of this, stated with the estimate: 10%; the middle value sits exactly at the limit.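

In this assay compound 4 gives > 10 mg/kg, which is a limit of the assay and not a number. The step therefore reads only as a number no lower from compound 3 to compound 4 (the limit leaves the size open), which gives a direction without a size and does not show whether methyl in place of hydrogen on a saturated chain carbon bound to a carbonyl carbon acts alike on both cores. Nothing here establishes that the change carries over from one core to the other, nor that it fails to, and the comparison stops at what the two steps allow: the same change on two cores in this assay, no change at the digits printed (within the scatter) from compound 1 to compound 2 and a number no lower (the limit leaves the size open) from compound 3 to compound 4; the limit leaves it open whether they differ

The compounds shown leave open how a longer chain such as butanoyl, or an amine or a carboxylic acid on the acyl chain, would read in this assay. No pair shown breaks down the difference between the core of compound 1 and the core of compound 3, so that difference remains unresolved.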